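Amine Variation on a Pyrimidine Core for Receptor Binding

The source may report more compounds than this note shows. Statements on the series, on what has been measured and on what is new or still open speak of the compounds shown alone.

Measured compounds:
compound 1 `CCCN(CCC)c1c(C)nc(-c2c(C)cc(C)cc2OC)nc1OC` gives 15 nM
compound 2 `CCCN(CCC)c1c(CC)nc(-c2c(C)cc(C)cc2OC)nc1OC` gives 22 nM
compound 3 `CCCc1nc(-c2c(C)cc(C)cc2OC)nc(OC)c1N(CCC)CCC` gives 76 nM

These three compounds were tested in an in vitro assay on IMR-32 cells for displacement of a labelled ligand from corticotropin-releasing factor receptor 1 (Homo sapiens); on this read-out lower numbers stand for stronger inhibition and higher numbers for weaker inhibition. Among them, compound 1 has the lowest number; compound 2 sits close to it, while compound 3 lies further away. The measured steps all concern the saturated chain attached to the core: a 1.5-fold higher number from compound 1 to compound 2 (0.17 log units; within the scatter), a 5.1-fold higher number from compound 1 to compound 3 (0.70 log units; beyond the scatter) and a 3.5-fold higher number from compound 2 to compound 3 (0.54 log units; beyond the scatter). The first is within the scatter, the other two are modest and beyond it.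

Compound 4 `CCC(CC)Nc1c(C)nc(-c2c(C)cc(C)cc2OC)nc1OC` is not yet measured. Its change from compound 1 is (pentan-3-yl)amino in place of dipropylamino on an aromatic carbon. Among the compounds with values here, none of the measured steps touches the amine; they all concern the chain on the other side of the core, so no measured step bears directly on this change, and the expectation rests on the compounds as a whole rather than on a matching step. The change is expected to cost little or nothing beyond the scatter, so compound 4 is expected at 25 nM, with a range from 8 nM to 80 nM, a step of a 1.7-fold higher number from compound 1 to compound 4 (0.22 log units; within the scatter) from compound 1.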

Compound 4, inhibition constant: 94 nM
Compound 4: middle estimate off by 3.8-fold (0.58 log units), on the low side; measured number outside the range, above it.
By their numbers in this assay, from the lowest: compounds 1 and 2 (each within the scatter of the next); then compounds 3 and 4 (each within the scatter of the next).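

In this assay, the amine on the aromatic carbon proves to be a position where the number can move beyond the scatter, with a 6.3-fold higher number from compound 1 to compound 4 (0.80 log units; beyond the scatter) on replacing dipropylamino with (pentan-3-yl)amino. Within the data shown here, the earlier compounds varied only the saturated chain on the core, so this is the first step to show that the amine cannot be exchanged freely while the rest of compound 1 stays the same. The exchange alters the shape of the amine substituent and also brings in a hydrogen-bond donor that dipropylamino lacks, and no measurement available here explains the higher number.

The compounds shown leave open which of these two differences goes with the step, as both arrive together in compound 4. A methyl(pentan-3-yl)amino group, which keeps the pentan-3-yl chain but has no hydrogen on the nitrogen, or a propylamino group, which keeps an unbranched propyl chain but retains that hydrogen, would separate the two differences on the core of compound 1.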